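Methyl-to-hydrogen step across two oxazole-type cores

A few compounds are considered here, and "the series" means these few. Any claim that something is new, unique, unknown or untested is made for them only; others in the source may bear on it.

Measured compounds:
- compound 1, `COC(=O)[C@@H]1COC(/C=C/c2ccc(C)cc2)=N1`, 17%
- compound 2, `COC(=O)[C@@H]1COC(/C=C/c2ccccc2)=N1`, 12.4%
- compound 3, `COC(=O)c1coc(/C=C/c2ccc(C)cc2)n1`, 100%

All three were run in an ADME assay on Vero cells (Chlorocebus sabaeus) for cytotoxicity, read by WST assay, tested at 100 ug/mL; on this read-out higher numbers stand for a weaker effect at the one concentration tested and lower numbers for a stronger effect. Compound 1 and compound 2 share one core and differ only by hydrogen in place of methyl on an aromatic carbon; that step, a number 4.6 percentage points lower from compound 1 to compound 2 (within the scatter), is small, so within this pair the methyl appears to make little difference to the read-out. Compound 3 carries a second core; how it differs from the core of compound 1 is not broken down here. What the two values show is that compound 3 stands far apart from both, with compound 1 lower by a wide margin and compound 2 lower by a still wider one, both gaps beyond the scatter.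

The unmeasured compound 4, `COC(=O)c1coc(/C=C/c2ccccc2)n1`, is related to compound 3 by hydrogen in place of methyl on an aromatic carbon. The place is worded identically to the earlier step, so it is the same change applied to the other core, and it occurs twice among the four compounds.

Expectation for compound 4 in this assay: because the matching step a number 4.6 percentage points lower from compound 1 to compound 2 (within the scatter) was within the scatter, the step of a number 4 percentage points lower from compound 3 to compound 4 (within the scatter) is estimated to be small as well, and compound 4 is expected to stay close to compound 3. The estimate for compound 4 is 96%, with a range from 80% to 108%. This rests on a single matched pair, and a core-dependent effect of the methyl cannot be ruled out from the data in hand.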

Compound 4, a percentage reported as activity, at one concentration (the size of the read-out at that concentration, not a potency): 102%
Compound 4: middle estimate off by 6 percentage points, on the low side; the range from low to high includes it.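

In this assay, hydrogen in place of methyl on an aromatic carbon of the core of compound 3 gives a number 2 percentage points higher from compound 3 to compound 4 (within the scatter), so the step is small on this core as well. Within these two matched pairs, the change carries from one core to the other with no difference in step size that can be told from the scatter: the same change on two cores in this assay, a number 4.6 percentage points lower (within the scatter) from compound 1 to compound 2 and a number 2 percentage points higher (within the scatter) from compound 3 to compound 4, 6.6 percentage points apart, within the scatter of two such steps This does not show that the methyl has no influence in general, since the comparison rests on only two pairs, on one read-out at a single concentration that gives no potency, and it does not explain the wide separation of compound 3 and compound 4 from compound 1 and compound 2.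

The compounds shown leave open whether the same agreement between cores would hold for a group other than methyl at this place, such as a methoxy group, a chlorine atom, an amine or a longer chain such as ethyl, or for a substituent elsewhere on the six-membered ring. Also open, on these data alone, is how either core would respond if a carboxylic acid or an amide stood in place of the methyl ester, a change that neither matched pair addresses.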